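This account rests on a few compounds, and the source may have more. Where it says the series, first, only, none or still open, it means among the compounds named here.

Working notes on the series. In an ADME assay on L02 cells (Homo sapiens) for cytotoxicity, read by MTT assay, with a stated time of 24 h (on this read-out higher numbers stand for weaker inhibition and lower numbers for stronger inhibition), compound 1 (`CCCC(O)(C#Cc1ccc(C(CC)(CC)C2=CN(CC)C(C(=O)NCCN(CC)CC)C2)cc1C)CCC`) gives > 50000 nM as a limit and not a number. Compound 2 (`CCN(CC)CCNC(=O)C1CC(C(CC)(CC)c2ccc(C#CC(O)C3CCC3)c(C)c2)=CN1CC`) gives > 50000 nM as a limit too. Compound 3 (`CCN(CC)CCNC(=O)C1CC=C(C(CC)(CC)c2ccc(C#CC(C)(C)O)c(C)c2)N1CC`) gives > 50000 nM as a limit again. Compound 3 stands at the limit of > 50000 nM in this assay, at which 3 of the 3 values shown sit, and no number is known for it.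

Compound 4 (`CCN(CC)CCNC(=O)C1CC=C(C(CC)(CC)c2ccc(C#CC(C)(O)CC)c(C)c2)N1CC`) follows with methyl in place of hydrogen on a saturated chain carbon, two bonds along the chain from an oxygen on a saturated carbon and a triple-bonded carbon as its change, methyl to ethyl. Within the data shown here, the only measured step is a step that the two limits leave unreadable from compound 1 to compound 2 and both its ends are limits, so it yields no size. In this assay the expected a number no higher from compound 3 to compound 4 (the limit leaves the size open) is none beyond the scatter. Compound 4 is estimated at 50000 nM within an expected range of 30000 nM to 100000 nM and will probably be reported only as a limit.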

Compound 4, half-maximal inhibitory concentration: > 50000 nM
Compound 4 was reported as a limit; the forecaster's own chance of this, stated with the estimate: 90%; the middle value lies on the limit itself.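

Compound 3 and compound 4 are both recorded only as limits in this assay, so no step can be read between them. The compounds shown leave open how any structural change alters cytotoxicity, with every result at the same ceiling: the limit of > 50000 nM in this assay, at which 4 of the 4 values shown sit.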